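Chain shortening on the shared core: compound 1 to compound 4

The source may report more compounds than this note shows. Statements on the series, on what has been measured and on what is new or still open speak of the compounds shown alone.

Compound 1 `CCCCCCc1cccc(N2CCNCC2)n1` is the reference point of this small set. Among the measured compounds shown here, in a functional assay on the whole organism with Mus musculus as the target, in the maximal electroshock model, with a stated time of 120 min (a lower number here means that less compound is needed, a higher number that more compound is needed for the effect), compound 1 gives 10 mg/kg, and this is the only number in the set. Compound 2 `CCCCCCC(CCCCCC)c1cccc(N2CCNCC2)n1` reaches only a limit, > 300 mg/kg in this assay. Compound 3 `CCCCCCCc1cccc(N2CCCCC2)n1` likewise reaches only a limit, > 300 mg/kg in this assay. Compound 1 thus stands alone at a measured dose, with the rest of the set at the limit of > 300 mg/kg in this assay, at which 2 of the 3 values shown sit. For the measured compounds named here, neither compound 2 nor compound 3 differs from compound 1 in one place only, so no single-change step is available between measured compounds.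

Compound 4 `CCCCCc1cccc(N2CCNCC2)n1` is the unmeasured member. It differs from compound 1 by hydrogen in place of methyl on a saturated chain carbon, five bonds along the chain from an aromatic carbon. The change is a shortening of the saturated chain by one carbon, with the shared core untouched. Without a measured step of this kind in the set, the expectation rests on compound 1 alone, and the step from compound 1 to compound 4 is expected to be small, within or only just beyond the scatter, as a 1.5-fold higher number from compound 1 to compound 4 (0.18 log units; within the scatter) in this assay. For compound 4 the minimum effective dose in this assay is estimated at 15 mg/kg, with a range from 5 mg/kg to 60 mg/kg.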

Compound 4, minimum effective dose: 10 mg/kg
Compound 4: the middle estimate sits 1.5-fold (0.18 log units) above what was measured, within the range that was stated.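

Among the compounds shown here, the step in this assay reads no change at the digits printed from compound 1 to compound 4 (within the scatter), which makes hydrogen in place of methyl on a saturated chain carbon, five bonds along the chain from an aromatic carbon, the first single-change step that can be read. At this position the two compounds cannot be told apart by minimum effective dose, so on the shared core the saturated chain does not need that carbon for the effect in this assay. The set now holds two compounds with a measured dose instead of one, while the other two remain at a limit of the assay and no step to them can be read: the limit of > 300 mg/kg in this assay, at which 2 of the 4 values shown sit.

On these data alone, whether a butyl or a propyl chain on the shared core would still give a measured dose in this assay stays open, so the point at which shortening begins to matter is not located. Also open, as far as these compounds go, is how a longer chain, or an amine or a carboxylic acid carried on the chain, would read with the core of compound 1 otherwise untouched.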